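The source may report more compounds than this note shows. Statements on the series, on what has been measured and on what is new or still open speak of the compounds shown alone.

Compound 1 `Cc1cc(=O)oc2cc(SCc3cccc(C(F)(F)F)c3)ccc12` carries a trifluoromethyl on the outer ring. In a functional assay on KBVIN cells (Homo sapiens) for antiproliferative activity, read by sulforhodamine B assay, with a stated time of 72 h (on this read-out higher numbers stand for weaker inhibition of growth and lower numbers for stronger inhibition of growth), compound 1 gives > 28500 nM, which is a limit of the measurement rather than a number. Compound 2 `Cc1cc(=O)oc2cc(SCc3cccc(C#N)c3)ccc12` differs from it only by cyano in place of trifluoromethyl on an aromatic carbon. In this assay compound 2 gives > 32500 nM, again a limit. The step that the two limits leave unreadable from compound 1 to compound 2 therefore cannot be read, since both values sit at limits: the limit of > 28500 nM in this assay, at which 1 of the 3 values shown sits, and (the limit of > 32500 nM in this assay, at which 1 of the 3 values shown sits).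

Compound 3 `CCc1cc(=O)c2ccc(OCc3cccc(C(F)(F)F)c3)c(C)c2o1` has a different core; how the two cores differ is not broken down here. In this assay compound 3 gives > 27600 nM, also a limit, as the limit of > 27600 nM in this assay, at which 1 of the 3 values shown sits, records.

Compound 4 `CCc1cc(=O)c2ccc(OCc3cccc(C#N)c3)c(C)c2o1` is not yet measured and differs from compound 3 by cyano in place of trifluoromethyl on an aromatic carbon, the same change as between compound 1 and compound 2. Because all three measured values sit at limits (the limit of > 27600 nM in this assay, at which 1 of the 3 values shown sits, (the limit of > 28500 nM in this assay, at which 1 of the 3 values shown sits), (the limit of > 32500 nM in this assay, at which 1 of the 3 values shown sits)), the step that the limit leaves unreadable from compound 3 to compound 4 is expected to stay unreadable. Compound 4 is estimated at 40000 nM, between 15000 nM and 120000 nM, most likely reported only as a limit.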

Compound 4, concentration for 50% growth inhibition: > 31300 nM
Compound 4 gave a limit, no number; the forecaster's own chance of this, stated with the estimate: 85%; the middle value is on the limit's open side.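

In this assay compound 4 gives > 31300 nM, which is a limit and not a number. Going by these compounds alone, compound 3 also stands at a limit, so no step from compound 3 to compound 4 can be read. The compounds shown leave open whether cyano in place of trifluoromethyl alters growth inhibition on either core, and how the four compounds rank against one another.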